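Changing the aryl group on the ring nitrogen of compound 1

This account rests on a few compounds, and the source may have more. Where it says the series, first, only, none or still open, it means among the compounds named here.

Compound 1 `COc1cc2c(Oc3ccc(NC(=O)c4nn(-c5ccccc5C(F)(F)F)c(=O)cc4C)cc3F)ccnc2cc1OCCCN1CCCC1` gives 130 nM in a functional assay on A549 cells (Homo sapiens) for inhibition, read by MTT assay, with a stated time of 72 h; on this read-out lower numbers stand for stronger inhibition and higher numbers for weaker inhibition.
Compound 2 `COc1cc2c(Oc3ccc(NC(=O)c4nn(-c5ccccc5C(F)(F)F)c(=O)cc4C)cc3F)ccnc2cc1OCCCN1CCCCC1` gives 140 nM in this assay.
Compound 3 `COc1cc2c(Oc3ccc(NC(=O)c4nn(-c5ccccc5C(F)(F)F)c(=O)cc4C)cc3F)ccnc2cc1OCCCN1CCC(C)CC1` gives 160 nM in this assay.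

Compound 1 has the lowest number of the three, but the steps of a 1.1-fold higher number from compound 1 to compound 2 (0.03 log units; within the scatter) and a 1.2-fold higher number from compound 1 to compound 3 (0.09 log units; within the scatter) are both within the scatter, so the three compounds cannot be told apart. Compound 4 `COc1cc2c(Oc3ccc(NC(=O)c4nn(-c5ccc(Cl)cc5)c(=O)cc4C)cc3F)ccnc2cc1OCCCN1CCCC1` differs from compound 1 in another place: 4-chlorophenyl in place of 2-(trifluoromethyl)phenyl on an aromatic nitrogen. The measured steps all change the amine at the chain end, far from this site, so none of them bears on this change, and there is no basis for expecting a step in either direction beyond the scatter. Compound 4 is therefore estimated near compound 1, at 200 nM, with a wide range from 50 nM to 800 nM, a step of a 1.5-fold higher number from compound 1 to compound 4 (0.19 log units; within the scatter) that is expected, not known.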

Compound 4, half-maximal inhibitory concentration: 230 nM
The estimate for compound 4 lay 1.2-fold (0.06 log units) below the measured number; low and high end bracket the measured number.
By their numbers in this assay, from the lowest: compounds 1, 2, 3 and 4 (each within the scatter of the next).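

In this assay, putting 4-chlorophenyl in place of 2-(trifluoromethyl)phenyl on the aromatic nitrogen gives a 1.8-fold higher number from compound 1 to compound 4 (0.25 log units; within the scatter). Within the data shown here, this is the first look at this site, since the earlier steps changed only the amine at the chain end, and it shows that this swap of aryl groups leaves no difference that can be told from the scatter. No measurement here bears on why.

The swap alters both the substituent and where it sits on the phenyl ring, so 2-chlorophenyl or 4-(trifluoromethyl)phenyl would be needed to separate the two. Going by these compounds, what a plain phenyl or a methyl on this nitrogen would give also stays open.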